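The source may report more compounds than this note shows. Statements on the series, on what has been measured and on what is new or still open speak of the compounds shown alone.

Compound 1 `N=C(NO)N/N=C/c1ccc(O)cc1` carries a hydroxy group on the aromatic ring of the shared core. In a functional assay on HL-60 cells (Homo sapiens) for antiproliferative activity (a lower number here means a stronger inhibitor, a higher number a weaker inhibitor), compound 1 gives > 100000 nM, a limit of the assay. Compound 2 `N=C(NO)N/N=C/c1ccc(Cl)cc1` gives in this assay > 100000 nM, again a limit. Compound 3 `COc1ccc(/C=N/NC(=N)NO)cc1` gives > 100000 nM, likewise a limit. The steps a step that the two limits leave unreadable from compound 1 to compound 2, a step that the two limits leave unreadable from compound 1 to compound 3 and a step that the two limits leave unreadable from compound 2 to compound 3 therefore carry no readable size, because of the limit of > 100000 nM in this assay, at which 3 of the 3 values shown sit. Compound 4 `N=C(NO)N/N=C/c1ccccc1` differs from compound 1 by hydrogen in place of hydroxy on an aromatic carbon. Among the compounds with values here, with no measured step of readable size, no direction can be drawn for the change to compound 4. Compound 4 is expected to give 150000 nM, estimated to lie between 50000 nM and 500000 nM. The step that the limit leaves unreadable from compound 1 to compound 4 is thus expected to stay within the scatter.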

Compound 4, half-maximal inhibitory concentration: 62000 nM
Estimate against measurement, compound 4: 2.4-fold (0.38 log units) above; the measured number falls inside the stated range.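

In this assay compound 4, with hydrogen on the aromatic carbon, is the only compound shown with a readable number, so a change at this position now has a floor. Replacing the hydroxy gives an at least 1.6-fold lower number from compound 1 to compound 4 (0.20 log units; that floor lies within the scatter), replacing the methoxy gives an at least 1.6-fold lower number from compound 3 to compound 4 (0.20 log units; that floor lies within the scatter), and replacing the chloro gives an at least 1.6-fold lower number from compound 2 to compound 4 (0.20 log units; that floor lies within the scatter). The true sizes of these steps stay unknown, and the steps among compound 1, compound 2 and compound 3 remain unreadable, because those three compounds sit at a limit: the limit of > 100000 nM in this assay, at which 3 of the 4 values shown sit.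

The compounds shown leave open whether any group at this position, such as an amine or a carboxylic acid, would give a number lower than that of compound 4.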